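Cyclohexyl in place of sec-butyl on the amine nitrogen

The compounds below may be only part of what the source reports. "The series", "measured", "known", "first", "only" and "open" are said of these compounds alone.

Compound 1 `CCC(C)NC(=C\C(=O)/C=C/c1ccc(O)c(OC)c1)/C=C/c1ccc(O)c(OC)c1` and compound 2 `COc1cc(/C=C/C(=O)/C=C(/C=C/c2ccc(O)c(OC)c2)NC2CCCCC2)ccc1O` make one pair; compound 3 `CCC(C)NC(=C\C(=O)/C=C/c1ccc(O)cc1)/C=C/c1ccc(O)cc1` and the unmeasured compound 4 `O=C(/C=C(/C=C/c1ccc(O)cc1)NC1CCCCC1)/C=C/c1ccc(O)cc1` make a second. The difference between the two cores is not broken down here. In an ADME assay on EA.hy 926 cells (Homo sapiens) for inhibition, read by MTT assay, with a stated time of 72 h (on this read-out higher numbers stand for weaker inhibition and lower numbers for stronger inhibition), compound 1 gives > 25000 nM, which is a limit of the assay. In this assay compound 2 gives > 25000 nM, again a limit. The change cyclohexyl in place of sec-butyl on an amine nitrogen thus yields a step that the two limits leave unreadable from compound 1 to compound 2, and the limit of > 25000 nM in this assay, at which 2 of the 3 values shown sit, is all that pair offers. In this assay, within the data shown here, compound 3 gives 22000 nM, the only number in the set. Compound 4 carries the same change, (cyclohexyl in place of sec-butyl on an amine nitrogen), at the same place. The step is expected to be a 1.1-fold higher number from compound 3 to compound 4 (0.06 log units; within the scatter), near flat, resting on a step that the two limits leave unreadable from compound 1 to compound 2 being unreadable and on compound 3 giving 22000 nM. Compound 4 is therefore estimated at 25000 nM, between 12000 nM and 50000 nM.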

Compound 4, half-maximal inhibitory concentration: 3300 nM
Compound 4: the middle estimate sits 7.6-fold (0.88 log units) above what was measured; measured number outside the range, below it.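

In this assay, cyclohexyl in place of sec-butyl on the amine nitrogen gives a 6.7-fold lower number from compound 3 to compound 4 (0.82 log units; beyond the scatter) on the core of compound 3. On the core of compound 1 the same change cannot be read, so the step is seen on one core only and carrying it from one core to the other is neither confirmed nor refuted. Neither a similar nor a different effect on that core can be claimed, and both compound 1 and compound 2 rest on a limit of the assay: the limit of > 25000 nM in this assay, at which 2 of the 4 values shown sit.

Still open, as far as these compounds go, is whether the step extends to other groups on the amine nitrogen, such as cyclopentyl or a longer chain. From the compounds shown here alone, a carboxylic acid on the cyclohexyl ring is equally open.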